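The source may hold more compounds than are shown below. What is called first, only, known or untested is meant among the compounds shown, and "the series" means these compounds.

Measured so far:
compound 1 `NC(=O)c1c(NC(=O)c2ccccc2F)sc2c1CCN(C(=S)Nc1cc(C(F)(F)F)cc(C(F)(F)F)c1)C2` — 13300 nM
compound 2 `Cc1ccccc1C(=O)Nc1sc2c(c1C(N)=O)CCN(C(=S)Nc1ccccc1Br)C2` — > 50000 nM

In a functional assay on MKN-74 cells (Homo sapiens) for antiproliferative activity, with a stated time of 24 h (on this read-out higher numbers stand for weaker inhibition and lower numbers for stronger inhibition), compound 1 gives 13300 nM, the only plain number among the two results shown. For compound 2 the result, > 50000 nM, is a limit of the assay and not a number. Compound 2 thus sits at the limit of > 50000 nM in this assay, at which 1 of the 2 values shown sits. Compound 3 `Cc1ccc(C(=O)Nc2sc3c(c2C(N)=O)CCN(C(=S)Nc2cc(C(F)(F)F)cc(C(F)(F)F)c2)C3)cc1` has not been measured. It is reached from compound 1 by a single change: 4-methylphenyl in place of 2-fluorophenyl on a carbonyl carbon. No pair of measured compounds shows this change on its own, so its size cannot be read from the numbers shown, and the only plain number available is that of compound 1. The step of a 1.1-fold higher number from compound 1 to compound 3 (0.05 log units; within the scatter) is therefore expected to be small, with no direction beyond the usual scatter. On that basis the expected value for compound 3 in this assay is 15000 nM, within a range from 5000 nM to 50000 nM.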

Compound 3, half-maximal inhibitory concentration: 14900 nM
Compound 3: the middle estimate sits 1.0-fold (0.00 log units) above what was measured; the measured number falls inside the stated range.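

In this assay, 4-methylphenyl in place of 2-fluorophenyl on a carbonyl carbon gives a 1.1-fold higher number from compound 1 to compound 3 (0.05 log units; within the scatter). This is the first step shown at this position, and it means that these two aryl groups cannot be told apart here, even though one carries a fluorine and the other a methyl, at different places on the ring. The results shown give no measured property of either group that could account for this outcome.

This is a single swap between two substituted phenyl rings, so it says little about the position in general. Going by these compounds, how this assay would read with a group of another kind on that carbonyl carbon, such as a longer alkyl chain, an amine or a ring bearing a carboxylic acid, remains open.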